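A few compounds are considered here, and "the series" means these few. Any claim that something is new, unique, unknown or untested is made for them only; others in the source may bear on it.

In a functional assay on HT cells (Homo sapiens) for antiproliferative activity, read by fluorescence, with a stated time of 72 h (a lower number here means a stronger inhibitor of growth, a higher number a weaker inhibitor of growth), compound 1 `CC(C)c1n[nH]c2c(NCc3ccc(-c4ccccn4)cc3)nc(SCC(O)CN)nc12` gives 55 nM while compound 2 `CSc1nc(NCc2ccc(-c3ccccn3)cc2)c2[nH]nc(C(C)C)c2n1` gives 783 nM and compound 3 `CC(C)c1n[nH]c2c(NCc3ccc(-c4ccccn4)cc3)nc(SC(C)C(C)O)nc12` gives 190 nM as the middle of the three numbers. Compound 4 `CC(C)c1n[nH]c2c(NCc3ccc(-c4ccccn4)cc3)nc(SCCNC(=N)N)nc12` departs from compound 3 through a group of 6 heavy atoms (3 carbon, 3 nitrogen; no ring) in place of a group of 5 heavy atoms (4 carbon, 1 oxygen; no ring), on a sulfur on a sulfur. For the measured compounds named here, two measured steps bear on this change: a 4.1-fold lower number from compound 2 to compound 3 (0.62 log units; beyond the scatter) as methyl gives way to 2-hydroxy-1-methylpropyl, and a 3.5-fold higher number from compound 1 to compound 3 (0.54 log units; beyond the scatter) as 3-amino-2-hydroxypropyl gives way to the same group. Among the measured compounds, only compound 1 holds nitrogen in that chain, so a modest step to a lower number is expected in this assay on this single precedent. The expected change is a 2.4-fold lower number from compound 3 to compound 4 (0.38 log units; beyond the scatter) as estimated here. Compound 4 is therefore estimated at 80 nM within a range of 25 nM to 250 nM for now.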

Compound 4, concentration for 50% growth inhibition: 390 nM
Compound 4: middle estimate off by 4.9-fold (0.69 log units), on the low side, and the stated range ends below it.
By their numbers in this assay, from the lowest: compound 1; then compound 3; then compounds 4 and 2 (each within the scatter of the next).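

Nitrogen in the chain on the sulfur does not by itself lower the number in this assay: the group of 6 heavy atoms gives a 2.1-fold higher number from compound 3 to compound 4 (0.31 log units; beyond the scatter) and a 7.1-fold higher number from compound 1 to compound 4 (0.85 log units; beyond the scatter). The step from the methyl group is a 2.0-fold lower number from compound 2 to compound 4 (0.30 log units; within the scatter), so this chain shows no clear gain over methyl. No measurement shown here accounts for this result. Going by these compounds, it remains open whether the amine, the hydroxyl or both set the value of compound 1; a plain 3-aminopropyl chain or a 2-aminoethyl chain would help separate them.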